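The source may report more compounds than this note shows. Statements on the series, on what has been measured and on what is new or still open speak of the compounds shown alone.

Compound 1 `CCO/N=C/Nc1cc(Cl)c(OC(C)C)c(Cl)c1`: 4.4
Compound 2 `CCO/N=C/Nc1cc(Cl)c(OCOC)c(Cl)c1`: 3.7
Compound 3 `C#CCc1c(Cl)cc(N/C=N/O)cc1Cl`: 2.8

In a physicochemical assay for lipophilicity, measured as octanol-water partition (a lower number here means a more polar compound, a higher number a more lipophilic compound), compound 3 stands lowest of the three measured numbers, with compound 2 the nearest above it and compound 1 the furthest, both gaps beyond the scatter. Compound 4 `C#CCc1c(Cl)cc(N/C=N/OCc2ccccc2)cc1Cl` differs from compound 3 by benzyl in place of hydrogen on an oxygen. Among the compounds with values here, no measured step covers this kind of change: the only step available, a number 0.70 log units lower from compound 1 to compound 2 (beyond the scatter), swaps one small group for another on a different oxygen, so it offers no direct guide. A large group entering in place of hydrogen is expected to raise this assay well beyond the scatter, by about a number 1.80 log units higher from compound 3 to compound 4 (beyond the scatter). Compound 4 is therefore estimated at 4.6, within a range from 4 to 5.2.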

Compound 4, partition coefficient: 4.2
For compound 4 the middle estimate is 0.40 log units above the measured one; measured number inside the range.
By their numbers in this assay, from the lowest: compound 3; then compound 2; then compounds 4 and 1 (each within the scatter of the next).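

In this assay, benzyl in place of hydrogen on an oxygen gives a number 1.40 log units higher from compound 3 to compound 4 (beyond the scatter), a large step and the only one shown at the oxygen bonded to the double-bonded nitrogen. The earlier step, a number 0.70 log units lower from compound 1 to compound 2 (beyond the scatter), concerned a different oxygen and swapped one group for another, so this result is the only measure of how far this position can move the number. Nothing available explains the size of this step. From the compounds shown here alone, whether a methyl, or a chain carrying an amine, on this oxygen would give a smaller or larger step stays open.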